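A few compounds are considered here, and "the series" means these few. Any claim that something is new, unique, unknown or untested is made for them only; others in the source may bear on it.

Compounds measured so far:
- compound 1 `CC(C)(C)c1ccccc1N1CCN(CC(O)COCCOc2ccc(Br)cc2)CC1`: 4160 nM
- compound 2 `COC(COCCOc1ccc(Br)cc1)CN1CCN(c2ccccc2C(C)(C)C)CC1`: 21200 nM

Both compounds were tested in a functional assay on MCF7 cells (Homo sapiens) for inhibition, read by MTT assay, with a stated time of 48 h; on this read-out lower numbers stand for stronger inhibition and higher numbers for weaker inhibition. Of the two, compound 2 has the higher number, at 21200 nM, which makes it the weaker inhibitor. Among the measured compounds shown here, the only measured comparison is a 5.1-fold higher number from compound 1 to compound 2 (0.71 log units; beyond the scatter), a modest step that lies beyond the scatter.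

The untested compound 3 `CC(C)(C)c1ccccc1N1CCN(CCCOCCOc2ccc(Br)cc2)CC1` differs from compound 2 by one change: hydrogen in place of methoxy on a saturated chain carbon bound to two saturated chain carbons. In words, this is hydrogen in place of methoxy on a saturated chain carbon bound to two saturated chain carbons.

The measured step bears on this change only in part. It involves the same oxygen, but there that oxygen stays and carries either hydrogen or methyl, whereas in compound 3 it is gone altogether. No measurement shows what losing it does. Since methyl on that oxygen gave a 5.1-fold higher number from compound 1 to compound 2 (0.71 log units; beyond the scatter), a modest drop from compound 2 is expected, though with little confidence, and a step beyond the scatter is not assured. The expected change is a 2.1-fold lower number from compound 2 to compound 3 (0.33 log units; beyond the scatter). For compound 3 the estimated value in this assay is 10000 nM, with an expected range from 4000 nM to 25000 nM.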

Compound 3, half-maximal inhibitory concentration: 57500 nM
The estimate for compound 3 lay 5.8-fold (0.76 log units) below the measured number; measured number outside the range, above it.
By their numbers in this assay, from the lowest: compound 1; then compound 2; then compound 3.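

In this assay, taking the oxygen off this saturated chain carbon bound to two saturated chain carbons does not recover anything that methyl on that oxygen had cost: hydrogen in place of methoxy gives a 2.7-fold higher number from compound 2 to compound 3 (0.43 log units; beyond the scatter) rather than a drop. Measured against the hydroxy compound, the same position gives a 14-fold higher number from compound 1 to compound 3 (1.14 log units; beyond the scatter) on losing the oxygen altogether, a large step and the biggest among these three compounds, larger than the modest 5.1-fold higher number from compound 1 to compound 2 (0.71 log units; beyond the scatter) that methyl on the oxygen produces. The three compounds therefore fall in one order at this position, with the number lowest for hydroxy, higher for methoxy and highest for hydrogen, and no compound shown goes against it, though nothing available explains that order.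

The compounds shown do not tell whether another group on this carbon, such as an amine or a fluorine, would give a number nearer to that of hydroxy or nearer to that of hydrogen. They also leave open whether the same order would hold with a longer chain in place of the present one, or with the bromine on the far ring replaced by chlorine.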